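Series notes: amine variation on a shared core

The source may hold more compounds than are shown below. What is called first, only, known or untested is meant among the compounds shown, and "the series" means these compounds.

Measured so far:
compound 1, `COCCNc1nc(-c2ccccc2)nc2ccccc12`, 26.8 ug/mL
compound 2, `CN1CCCN(c2nc(-c3ccccc3)nc3ccccc23)CC1`, 20.1 ug/mL
compound 3, `CC(C)Nc1nc(-c2ccccc2)nc2ccccc12`, 4.11 ug/mL

In a functional assay on HCT-15 cells (Homo sapiens) for cytotoxicity, read by sulforhodamine B assay (a lower number here means a stronger inhibitor, a higher number a weaker inhibitor), compound 3 holds the lowest number of the three, beyond the scatter from both others: a 6.5-fold lower number from compound 1 to compound 3 (0.81 log units; beyond the scatter) and a 4.9-fold lower number from compound 2 to compound 3 (0.69 log units; beyond the scatter). Compound 4, `CNc1nc(-c2ccccc2)nc2ccccc12`, differs from compound 3 by methyl in place of isopropyl on a nitrogen on an aromatic ring. Within the data shown here, no measured step exchanges one small alkyl for another on this nitrogen; the two steps that end at compound 3 both replace a larger group, 2-methoxyethyl or 4-methyl-1,4-diazepan-1-yl, with isopropyl and both give lower numbers. Whether shrinking further to methyl keeps that gain or reverses it cannot be read from these three compounds. A modest rise in this assay is expected, not clearly beyond the scatter, so compound 4 is estimated at 8 ug/mL, between 3 ug/mL and 22 ug/mL, which means an expected step of a 1.9-fold higher number from compound 3 to compound 4 (0.29 log units; within the scatter).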

Compound 4, half-maximal inhibitory concentration: 21.2 ug/mL
Beside the measured number, compound 4's estimate is 2.7-fold (0.42 log units) below it, within the range that was stated.
By their numbers in this assay, from the lowest: compound 3; then compounds 2, 4 and 1 (each within the scatter of the next).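

In this assay the lower number of compound 3 does not carry over to the smaller alkyl group on this nitrogen: methyl in place of isopropyl gives a 5.2-fold higher number from compound 3 to compound 4 (0.71 log units; beyond the scatter) and so loses the gain that isopropyl showed over the two larger amines. Compound 4 instead sits level with those amines, with a 1.1-fold higher number from compound 2 to compound 4 (0.02 log units; within the scatter) and a 1.3-fold lower number from compound 1 to compound 4 (0.10 log units; within the scatter), which leaves compound 3 alone apart from the other three and shows that a smaller group on this nitrogen does not by itself give a lower number. No measured evidence bears on why isopropylamino stands apart from methylamino.

From the compounds shown here alone, whether ethyl or cyclopropyl on this nitrogen holds the number of compound 3 remains open. So does whether a branched group larger than isopropyl, such as tert-butyl or cyclopentyl, goes lower still or reverses the gain.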